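One Methyl More: Reading a Small Change Forward

This account rests on a few compounds, and the source may have more. Where it says the series, first, only, none or still open, it means among the compounds named here.

The study rests on three measured compounds. Compound 1 `CCc1ccccc1OCC(O)COc1ccc2c(O)c([N+](=O)[O-])c(=O)oc2c1` and compound 2 `CC(C)c1ccccc1OCC(O)COc1ccc2c(O)c([N+](=O)[O-])c(=O)oc2c1` share a core and differ in one place: methyl in place of hydrogen on a saturated chain carbon bound to an aromatic carbon and a saturated chain carbon. In a functional assay on ileum (Cavia porcellus) for antagonist activity (on this read-out lower numbers stand for stronger inhibition and higher numbers for weaker inhibition), compound 1 gives 2700 nM, while compound 2 gives 160 nM, a step of a 17-fold lower number from compound 1 to compound 2 (1.23 log units; beyond the scatter). Compound 3 `CCCc1c(OCC(O)COc2ccc3c(O)c([N+](=O)[O-])c(=O)oc3c2C)ccc(C(C)=O)c1O` stands on a different core, and the difference between its core and the core of compound 1 is not broken down here. In this assay compound 3 gives 25 nM, the lowest of the three numbers, with compound 2 nearest to it and compound 1 furthest.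

Compound 4 `CCCc1c(OCC(O)COc2ccc3c(O)c([N+](=O)[O-])c(=O)oc3c2CC)ccc(C(C)=O)c1O` has not been measured. It differs from compound 3 in one place: methyl in place of hydrogen on a saturated chain carbon bound to an aromatic carbon. Within the data shown here, this is the same kind of change as the one between compound 1 and compound 2, though not the same change: there the carbon taking the methyl is bound to an aromatic carbon and a saturated chain carbon, here it is bound to an aromatic carbon only, and the two pairs sit on different cores. Among the measured compounds shown here, the one step of this kind on record, a 17-fold lower number from compound 1 to compound 2 (1.23 log units; beyond the scatter), is large. For the measured compounds named here, only that single example exists, and its place differs from the new one. The account expects a lowering for compound 4, but a smaller one, estimated as a 2.1-fold lower number from compound 3 to compound 4 (0.32 log units; beyond the scatter). Compound 4 is expected to give 12 nM in this assay, with the estimate spanning 3 nM to 50 nM.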

Compound 4, half-maximal inhibitory concentration: 50 nM
Estimate against measurement, compound 4: 4.2-fold (0.62 log units) below; the range from low to high includes it.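

In this assay, methyl in place of hydrogen gives a large step on the core of compound 1, a 17-fold lower number from compound 1 to compound 2 (1.23 log units; beyond the scatter), whereas on the core of compound 3 the step is a 2.0-fold higher number from compound 3 to compound 4 (0.30 log units; within the scatter), so the large effect seen on the first core does not carry over to the second. The two steps differ by more than their scatter, which means the earlier step cannot be read forward as a general rule for this change in the series: the same change on two cores in this assay, a 17-fold lower number (1.23 log units; beyond the scatter) from compound 1 to compound 2 and a 2.0-fold higher number (0.30 log units; within the scatter) from compound 3 to compound 4, 34-fold (1.53 log units) apart, beyond the scatter of two such steps. This does not show that the core alone sets the outcome: the carbon taking the methyl is bound to an aromatic carbon and a saturated chain carbon in one pair and to an aromatic carbon only in the other, and with a single pair of each kind the two differences cannot be separated.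

The compounds shown leave open whether the change would give a large step on the core of compound 3 at a carbon bound to both an aromatic carbon and a saturated chain carbon. They also leave open how a longer chain, an amine or a carboxylic acid would read in this assay on a saturated chain carbon bound to an aromatic carbon.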